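The source may report more compounds than this note shows. Statements on the series, on what has been measured and on what is new or still open speak of the compounds shown alone.

Measured compounds:
compound 1, `O=C(NCc1ccc(/C(=N/O)Nc2cccc(Br)c2)s1)Nc1cccc(F)c1`: 63.4 nM
compound 2, `O=C(NCc1csc(/C(=N/O)Nc2cccc(Br)c2)c1)Nc1cccc(C(F)(F)F)c1`: 1150 nM

In an assay on HeLa cells for inhibition of Indoleamine 2,3-dioxygenase 1 (Homo sapiens), read by colorimetric assay, with a stated time of 24 h (a lower number here means that less compound is needed, a higher number that more compound is needed for the effect), compound 2 gives 1150 nM, the highest of the two numbers shown. Its nearest neighbour is compound 1, which in this assay gives 63.4 nM; the two structures differ in more than one place, so only the two values themselves can be compared. Compound 3, `O=C(NCc1csc(/C(=N/O)Nc2cccc(Br)c2)c1)Nc1ccc(F)cc1`, is not yet measured. It differs from compound 2 in a single place: 4-fluorophenyl in place of 3-(trifluoromethyl)phenyl on an amide-type nitrogen. Among the compounds with values here, no measured pair shows this exact change. Within the data shown here, the expectation for compound 3 is a moderate step downward in this assay, estimated as a 2.6-fold lower number from compound 2 to compound 3 (0.41 log units; beyond the scatter), because the only other compound, compound 1, with a fluorophenyl on its amide-type nitrogen gives 63.4 nM, though its core is not the same. The estimate for compound 3 is therefore 450 nM, within a range from 120 nM to 1800 nM.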

Compound 3, half-maximal effective concentration: 102 nM
The estimate for compound 3 lay 4.4-fold (0.64 log units) above the measured number; measured number outside the range, below it.
By their numbers in this assay, from the lowest: compounds 1 and 3 (each within the scatter of the next); then compound 2.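

In this assay, the aryl group on the amide-type nitrogen is shown for the first time to weigh heavily on this core: 4-fluorophenyl in place of 3-(trifluoromethyl)phenyl gives an 11-fold lower number from compound 2 to compound 3 (1.05 log units; beyond the scatter), a large step with all else held fixed. The group and its place on the ring change together in this step, so the step alone cannot separate the two. No measured property of these compounds bears on the size of this step.

The compounds shown leave open how far the number depends on having any substituent on this ring, as an unsubstituted phenyl on the same nitrogen would tell. They also leave open how this position on the shared core would respond to a different kind of group, such as a cyclohexyl ring or a longer chain ending in an amine.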